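Urea Aryl Variation Read at a Single Concentration

The source may report more compounds than this note shows. Statements on the series, on what has been measured and on what is new or still open speak of the compounds shown alone.

Three compounds share one core and differ only in the aryl group on the urea nitrogen. Compound 1 `COc1cc(Cl)cc(-c2nn(-c3cccc(NC(=O)Nc4ccc(Cl)c(C(F)(F)F)c4)c3)cc2-c2ccncc2)c1` gives 92% in a functional assay on U-251 cells (Homo sapiens) for inhibition, read by sulforhodamine B assay, with a stated time of 48 h, tested at 0.1 uM; on this read-out higher numbers stand for a weaker effect at the one concentration tested and lower numbers for a stronger effect. Compound 2 `COc1cc(Cl)cc(-c2nn(-c3cccc(NC(=O)Nc4cc(C(F)(F)F)cc(C(F)(F)F)c4)c3)cc2-c2ccncc2)c1` gives 91% in this assay. Compound 3 `COc1cc(Cl)cc(-c2nn(-c3cccc(NC(=O)Nc4ccc(Cl)c(Cl)c4)c3)cc2-c2ccncc2)c1` gives 92% in this assay, level with compound 1 and within the scatter of compound 2. Going by the values given here, the only step between measured compounds that differ in one place, no change at the digits printed from compound 1 to compound 3 (within the scatter), also lies within the scatter.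

Compound 4 `COc1cc(Cl)cc(-c2nn(-c3cccc(NC(=O)Nc4cccc(C(F)(F)F)c4)c3)cc2-c2ccncc2)c1` differs from compound 3 in one place: 3-(trifluoromethyl)phenyl in place of 3,4-dichlorophenyl on an amide-type nitrogen. The step from compound 1 to compound 3 bears on this change because no change at the digits printed from compound 1 to compound 3 (within the scatter) shows that swapping chloro and trifluoromethyl on that aromatic ring left the read-out where it was. Among the compounds with values here, no measured step removes a substituent from that ring outright, so the expectation rests on the three near-identical values. Compound 4 is therefore expected to give 91%, with a range from 82% to 99%. The step of a number 1 percentage points lower from compound 3 to compound 4 (within the scatter) is expected to stay within the scatter.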

Compound 4, a percentage reported as activity, at one concentration (the size of the read-out at that concentration, not a potency): 93%
The estimate for compound 4 lay 2 percentage points below the measured number; the measured number falls inside the stated range.
By their numbers in this assay, from the lowest: compounds 2, 1, 3 and 4 (each within the scatter of the next).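

In this assay, going by these compounds alone, taking a substituent off the aryl ring on the urea nitrogen leaves the read-out within the scatter, which no earlier step had tested: hydrogen in place of chloro on an aromatic carbon gives a number 1 percentage points higher from compound 1 to compound 4 (within the scatter), and removing the second trifluoromethyl group gives a number 2 percentage points higher from compound 2 to compound 4 (within the scatter) at the one concentration tested. Replacing 3,4-dichlorophenyl with 3-(trifluoromethyl)phenyl on the amide-type nitrogen likewise gives a number 1 percentage points higher from compound 3 to compound 4 (within the scatter). Among these four compounds, then, neither the chloro nor the second trifluoromethyl group is tied to a change beyond the scatter in this read-out.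

From the compounds shown here alone, it remains open whether an unsubstituted phenyl, or an aryl ring bearing an amine, a carboxylic acid or a methoxy group, would shift the read-out on this nitrogen. No supporting evidence is available to explain why these values stay so close.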